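Moving the ring nitrogen in a pyridyl alkyne series

The compounds below may be only part of what the source reports. "The series", "measured", "known", "first", "only" and "open" are said of these compounds alone.

Compound 1 `Cc1c(C#Cc2ccc(CCC(=O)O)cc2)cc(Cl)nc1Cl`: 43.7 nM
Compound 2 `O=C(O)CCc1ccc(C#Cc2ccc(Cl)nc2)cc1`: 708 nM
Compound 3 `O=C(O)CCc1ccc(C#Cc2cccnc2)cc1`: 6030 nM

In an in vitro functional assay on 1321-N1 cells for agonist activity at Free fatty acid receptor 1 (Homo sapiens), read by fluorescence, spectrophotometry and calcium flux (a higher number here means that more compound is needed for the effect, a lower number that less compound is needed), compound 3 gives 6030 nM, the highest number of the three; compound 2 at 708 nM is its nearest neighbour, and compound 1 at 43.7 nM is furthest away. Within the data shown here, the only single-change step measured, an 8.5-fold higher number from compound 2 to compound 3 (0.93 log units; beyond the scatter), concerns a chloro group rather than the ring itself. Compound 4 `O=C(O)CCc1ccc(C#Cc2ccccn2)cc1` differs from compound 3 by pyridin-2-yl in place of pyridin-3-yl on a triple-bonded carbon. Among the measured compounds shown here, no measured step bears on this kind of change, so nothing beyond the scatter is expected, though the uncertainty is wide. Compound 4 is therefore expected to give 6000 nM, with a range from 1500 nM to 25000 nM. That estimate means a 1.0-fold lower number from compound 3 to compound 4 (0.00 log units; within the scatter), an expectation rather than a measurement.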

Compound 4, half-maximal effective concentration: 13200 nM
Estimate against measurement, compound 4: 2.2-fold (0.34 log units) below; the range from low to high includes it.
By their numbers in this assay, from the lowest: compound 1; then compound 2; then compound 3; then compound 4.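

Exchanging pyridin-3-yl for pyridin-2-yl on the triple-bonded carbon gives a 2.2-fold higher number from compound 3 to compound 4 (0.34 log units; beyond the scatter), so the ring itself matters at this position, even with its atoms unchanged. Among these compounds, until now, the only single-change step concerned a chloro group on the ring, not how the ring is attached. No available evidence bears on why these two rings differ. The compounds shown leave open how pyridin-4-yl or a plain phenyl ring would compare at this position. They also leave open whether a chloro group on the pyridin-2-yl ring would lower the number, as it does on the ring of compound 2.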